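Changing the amide group on a shared core

The source may hold more compounds than are shown below. What is called first, only, known or untested is meant among the compounds shown, and "the series" means these compounds.

compound 1 `N#CC1(NC(=O)[C@@H]2C[C@@H](S(=O)(=O)c3ccccc3)C[C@H]2C(=O)N2CCNCC2)CC1`: 1340 nM
compound 2 `N#CC1(NC(=O)[C@@H]2C[C@@H](S(=O)(=O)c3ccccc3)C[C@H]2C(=O)N2CCC(O)CC2)CC1`: 371 nM
compound 3 `N#CC1(NC(=O)[C@@H]2C[C@@H](S(=O)(=O)c3ccccc3)C[C@H]2C(=O)Nc2ccc(F)cc2)CC1`: 391 nM

All three compounds were tested in a functional assay on A20 cells (Mus musculus) for inhibition, with stated times of 1 h, 16 h and 24 h; a lower number here means a stronger inhibitor, a higher number a weaker inhibitor. Compound 3 stands level with compound 2, as the step between them is a 1.1-fold higher number from compound 2 to compound 3 (0.02 log units; within the scatter). Only compound 1 stands apart, with a 3.4-fold lower number from compound 1 to compound 3 (0.53 log units; beyond the scatter).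

The next compound, compound 4 `N#CC1(NC(=O)[C@@H]2C[C@@H](S(=O)(=O)c3ccccc3)C[C@H]2C(=O)N2CC(O)C2)CC1`, carries 3-hydroxyazetidin-1-yl in place of (4-fluorophenyl)amino on a carbonyl carbon.

Going by the values given here, two measured steps bear on this change. Replacing piperazin-1-yl with 4-hydroxypiperidin-1-yl gave a 3.6-fold lower number from compound 1 to compound 2 (0.56 log units; beyond the scatter), and replacing it with (4-fluorophenyl)amino gave a 3.4-fold lower number from compound 1 to compound 3 (0.53 log units; beyond the scatter). Two quite different groups on this carbonyl carbon therefore gave matching numbers. The closest relative of compound 4 is compound 2 at 371 nM, which also has a hydroxy-bearing ring there, though a six-membered one. No four-membered ring has been measured, so the estimate stays uncertain. Any change is expected to stay small, perhaps slightly upward, in this assay. The expected result is a 1.2-fold higher number from compound 3 to compound 4 (0.06 log units; within the scatter), no step beyond the scatter. For compound 4 the estimated value is 450 nM, with an expected range of 180 nM to 1100 nM.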

Compound 4, half-maximal inhibitory concentration: 572 nM
The estimate for compound 4 lay 1.3-fold (0.10 log units) below the measured number; low and high end bracket the measured number.
By their numbers in this assay, from the lowest: compounds 2, 3 and 4 (each within the scatter of the next); then compound 1.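

In this assay, the small 3-hydroxyazetidin-1-yl ring behaves much like the two larger groups: a 1.5-fold higher number from compound 3 to compound 4 (0.17 log units; within the scatter) and a 1.5-fold higher number from compound 2 to compound 4 (0.19 log units; within the scatter) both leave it level with them. On this carbonyl carbon, neither going from the six-membered hydroxy-bearing ring to the four-membered one nor giving up the aromatic (4-fluorophenyl)amino group moves the number past the usual scatter, so this position tolerates quite different groups among those tested. Compound 1 remains the one apart, since a 2.3-fold lower number from compound 1 to compound 4 (0.37 log units; beyond the scatter) adds a third replacement of piperazin-1-yl that lands clear of it, although nothing measured here explains why these groups give these numbers.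

The compounds shown leave open whether the five-membered 3-hydroxypyrrolidin-1-yl or the six-membered morpholin-4-yl, which keeps a ring of the same size as piperazin-1-yl but has oxygen in place of its second nitrogen, would sit with compounds 2, 3 and 4 or with compound 1. They also leave open how a group with a longer chain ending in a carboxylic acid or a dimethylamino group would fare on this same carbonyl carbon.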